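A Ring for a Chain on the Double-Bonded Nitrogen

This account rests on a few compounds, and the source may have more. Where it says the series, first, only, none or still open, it means among the compounds named here.

Of the compounds shown here, two built on a shared core have so far been tested in an ADME assay on HEp-2 cells (Homo sapiens) for cytotoxicity, read by trypan blue exclusion, with a stated time of 24 h; on this read-out higher numbers stand for lower toxicity in this test and lower numbers for higher toxicity in this test. Compound 1 `C/C(CC(C)C)=N\N=C1/SCC(=O)N1CN1C(=O)c2ccccc2C1=O` gives 99 ug/mL in this assay. Among the compounds with values here, compound 2 `C/C(CC(C)C)=N\N=C1/SCC(=O)N1Cc1ccc([N+](=O)[O-])cc1` gives 32 ug/mL in this assay, the lower of the two numbers; its only neighbour, compound 1, stands higher by a gap that lies beyond the usual scatter of such measurements.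

Compound 3 `O=C1CS/C(=N\N=C2CCCC2)N1Cc1ccc([N+](=O)[O-])cc1` has not yet been measured in this assay. Compared with compound 2 it differs in one place: a group of 6 heavy atoms (5 carbon, 1 nitrogen; one five-membered non-aromatic ring of carbon only) in place of a group of 7 heavy atoms (6 carbon, 1 nitrogen; no ring), on a double-bonded nitrogen. Within the data shown here, no pair of measured compounds shows a change of this kind, so nothing in the data speaks for a move in either direction. The expected step from compound 2 to compound 3 is therefore no larger than the scatter a 1.1-fold higher number from compound 2 to compound 3 (0.04 log units; within the scatter). Compound 3 is expected to give about 35 ug/mL in this assay, within a likely range from 15 ug/mL to 80 ug/mL.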

Compound 3, half-maximal cytotoxic concentration: 28 ug/mL
Compound 3: middle estimate off by 1.3-fold (0.10 log units), on the high side; measured number inside the range.
By their numbers in this assay, from the lowest: compounds 3 and 2 (each within the scatter of the next); then compound 1.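

Within the data shown here, on the double-bonded nitrogen, a five-membered non-aromatic ring of carbon only in place of the open chain gives a 1.1-fold lower number from compound 2 to compound 3 (0.06 log units; within the scatter) in this assay, the first reading of any change at this position. For this pair, then, a ring and an open chain at this place cannot be told apart on this read-out, even though the group also holds one heavy atom fewer. No measurement at hand bears on why the two groups read alike.

As far as these compounds go, what a six-membered ring of carbon, a longer chain or a group carrying an amine or a carboxylic acid would do on this nitrogen stays open. Among these compounds, also open is whether the same change would read alike on compound 1, whose other group differs from the one that compound 2 and compound 3 share.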